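The source may report more compounds than this note shows. Statements on the series, on what has been measured and on what is new or still open speak of the compounds shown alone.

Measured in a functional assay on HL-60 cells (Homo sapiens) for antiproliferative activity, read by MTT assay, with a stated time of 48 h; on this read-out lower numbers stand for stronger inhibition and higher numbers for weaker inhibition:
Compound 1 `CCN(CC)CCCn1c(N)c(-c2nc3ccccc3[nH]2)c2nc(C#N)c(C#N)nc21`: > 730 nM (a limit)
Compound 2 `CN1CCN(CCCn2c(N)c(-c3nc4ccccc4[nH]3)c3nc(C#N)c(C#N)nc32)CC1`: 750 nM

For the measured compounds named here, compound 2, at 750 nM, holds the only actual number in this small set. The entry for compound 1 is a limit and not a number.

Compound 3 `CCN(CC)CCCCn1c(N)c(-c2nc3ccccc3[nH]2)c2nc(C#N)c(C#N)nc21` has not yet been measured. Its change from compound 2 is (diethylamino)methyl in place of 4-methylpiperazin-1-yl on a saturated chain carbon, three bonds along the chain from an aromatic nitrogen. Cut one bond further out, this reads 3-(4-methylpiperazin-1-yl)propyl to 4-(diethylamino)butyl.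

Going by the values given here, the one measured step that bears on this is a step that the limit leaves unreadable from compound 1 to compound 2, and it exchanged the same two amine ends on the shorter chain. Its size cannot be read, so it offers no direction. Among the compounds with values here, the only further guide is the limit of > 730 nM in this assay, at which 1 of the 2 values shown sits.

No step beyond the usual scatter is therefore expected in this assay. The expected change is a 1.1-fold higher number from compound 2 to compound 3 (0.03 log units; within the scatter). For compound 3 the estimated value is 800 nM, with an expected range of 350 nM to 1800 nM.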

Compound 3, half-maximal inhibitory concentration: 460 nM
Compound 3: the middle estimate sits 1.7-fold (0.24 log units) above what was measured; measured number inside the range.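

In this assay, compound 3 supplies a second actual number, so the exchange of 3-(4-methylpiperazin-1-yl)propyl for 4-(diethylamino)butyl can now be read, and it comes to a 1.6-fold lower number from compound 2 to compound 3 (0.21 log units; within the scatter). On this evidence the two amine-bearing chains cannot be told apart at this position. The entry for compound 1 is a limit, so keeping the diethylamino end and going to the longer chain gives only a floor, an at least 1.5-fold lower number from compound 1 to compound 3 (0.20 log units; that floor lies within the scatter): the limit of > 730 nM in this assay, at which 1 of the 3 values shown sits.

Going by these compounds, the step from compound 1 to compound 2 still cannot be read, so it remains open whether the amine end matters on the shorter chain. Also open, on these data alone, is how a 4-(4-methylpiperazin-1-yl)butyl group, a morpholine end or a longer chain such as 5-(diethylamino)pentyl would read in this assay.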